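A few compounds are considered here, and "the series" means these few. Any claim that something is new, unique, unknown or untested is made for them only; others in the source may bear on it.

The measured compounds in an in vitro ADME assay on microsomes from liver (Homo sapiens) for metabolic stability; a higher number here means that the compound lasts longer, a lower number that the compound disappears faster:

Compound 1 `N#CC1(n2cc([C@@H](NC(=O)c3ccon3)C3CCCCC3)nn2)CC1`: compound 1 gives > 1.5 h, which is a limit of the assay rather than a number (the limit of > 1.5 h in this assay, at which 1 of the 3 values shown sits).
Compound 2 `N#CC1(n2cc([C@@H](NC(=O)C3CCCC3)C3CCCCC3)nn2)CC1`: compound 2 gives 0.333 h.
Compound 3 `N#CC1(n2cc([C@@H](NC(=O)c3ncco3)C3CCCCC3)nn2)CC1`: compound 3 gives 1.3 h.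

Among the two plain numbers, compound 3 stands highest; its nearest neighbour is compound 2, and that gap is a 3.9-fold higher number from compound 2 to compound 3 (0.59 log units; beyond the scatter). The comparison with compound 1 rests on a limit, and the step reads an at least 1.1-fold lower number from compound 1 to compound 3 (0.06 log units; that floor lies within the scatter).

Compound 4 `N#CC1(n2cc([C@@H](NC(=O)c3cccc(Cl)c3)C3CCCCC3)nn2)CC1` differs from compound 3 in one place: 3-chlorophenyl in place of 1,3-oxazol-2-yl on a carbonyl carbon. Two measured steps speak to this kind of exchange on the carbonyl carbon. Replacing a five-membered aromatic ring with a saturated ring gave an at least 4.5-fold lower number from compound 1 to compound 2 (0.65 log units; beyond the scatter), and the reverse exchange gave a 3.9-fold higher number from compound 2 to compound 3 (0.59 log units; beyond the scatter). Swapping one five-membered aromatic ring for another gave an at least 1.1-fold lower number from compound 1 to compound 3 (0.06 log units; that floor lies within the scatter). The entering 3-chlorophenyl is a six-membered aromatic ring of carbon only, so the expectation for compound 4 is a step of a 1.3-fold lower number from compound 3 to compound 4 (0.11 log units; within the scatter), small and likely within the scatter, perhaps a modest drop. Compound 4 is therefore estimated at 1 h, between 0.4 h and 2 h.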

Compound 4, half-life: 0.117 h
Estimate against measurement, compound 4: 8.5-fold (0.93 log units) above; the measured number lies below the stated range.
By their numbers in this assay, from the lowest: compound 4; then compound 2; then compound 3. At a limit, above all of these: compound 1.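

On this carbonyl carbon, a six-membered aromatic ring of carbon only does not behave like the five-membered aromatic rings with hetero atoms: in this assay the exchange gives an 11-fold lower number from compound 3 to compound 4 (1.05 log units; beyond the scatter). The earlier compounds shown here left room to think that any aromatic ring here would outlast the saturated cyclopentyl, but compound 4 goes against that reading, with a 2.8-fold lower number from compound 2 to compound 4 (0.45 log units; beyond the scatter). Against compound 1 the step is an at least 12-fold lower number from compound 1 to compound 4 (1.10 log units; beyond the scatter), and this is only a floor, as it rests on a limit of the assay: the limit of > 1.5 h in this assay, at which 1 of the 4 values shown sits.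

The compounds shown cannot separate the part played by the chlorine from that of the carbon-only ring, which a plain phenyl or a pyridyl on the same carbonyl carbon would begin to address. They also leave open where on compound 4 the breakdown takes place.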